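Hydroxy on the flat biaryl benzimidazole series

The compounds below may be only part of what the source reports. "The series", "measured", "known", "first", "only" and "open" are said of these compounds alone.

- compound 1 `FC(F)(F)Oc1ccc(-c2ccc(-c3ccc(-c4nc5ccccc5[nH]4)cc3)cc2)cc1`: 100000 nM
- compound 2 `COc1ccc(-c2ccc(-c3ccc(-c4nc5ccccc5[nH]4)cc3)cc2)cc1`: 100000 nM
- compound 3 `CN(C)c1ccc(-c2ccc(-c3ccc(-c4nc5ccccc5[nH]4)cc3)cc2)cc1`: 100000 nM

In a functional assay on A2780 cells (Homo sapiens) for inhibition, read by sulforhodamine B assay (a lower number here means a stronger inhibitor of growth, a higher number a weaker inhibitor of growth), compound 2 gives 100000 nM, level with compound 1 and compound 3 at the digits available. The next compound to be tested is compound 4 `COc1ccc(-c2ccc(-c3ccc(-c4nc5c(O)cccc5[nH]4)cc3)cc2)cc1`, which departs from compound 2 as follows: hydroxy in place of hydrogen on an aromatic carbon. In short, hydroxy stands in place of hydrogen on an aromatic carbon.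

Among the compounds with values here, three measured steps bear on this only indirectly: no change at the digits printed from compound 1 to compound 2 (within the scatter), no change at the digits printed from compound 2 to compound 3 (within the scatter) and no change at the digits printed from compound 1 to compound 3 (within the scatter). All three exchange the group that compound 2 carries as methoxy, and none alters the ring that receives the hydroxy. The data therefore hold no direct measure of this change. The series so far has shown no response to substitution, so the leading expectation is no step beyond the scatter, as in the flat result no change at the digits printed from compound 2 to compound 3 (within the scatter). An untested site can still behave differently, so the uncertainty is left open towards stronger inhibition of growth. The expected step is a 2.0-fold lower number from compound 2 to compound 4 (0.30 log units; within the scatter). For compound 4 the estimated value in this assay is 50000 nM, with an expected range from 3000 nM to 100000 nM.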

Compound 4, concentration for 50% growth inhibition: 8640 nM
The estimate for compound 4 lay 5.8-fold (0.76 log units) above the measured number, and the stated range covers the measured number.
By their numbers in this assay, from the lowest: compound 4; then compounds 1, 2 and 3 (each within the scatter of the next).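

In this assay, the change from 1H-benzimidazol-2-yl to 4-hydroxy-1H-benzimidazol-2-yl gives a 12-fold lower number from compound 2 to compound 4 (1.06 log units; beyond the scatter), the only step beyond the scatter among those shown. The exchanges among trifluoromethoxy, methoxy and dimethylamino at the other end of the molecule gave nothing comparable, as in no change at the digits printed from compound 1 to compound 3 (within the scatter), so within these four compounds the number responds to a substituent on the six-membered aromatic ring of the fused system and not to those exchanges. Nothing shown accounts for the size of this step or identifies what the hydroxy does at this carbon.

As far as these compounds go, it remains open whether the gain is specific to hydroxy, a question that a methoxy or an amine on the same carbon would address, and whether hydroxy on another carbon of this ring would give a similar step. From the compounds shown here alone, it is also open whether the end group stays without effect once the hydroxy is present, which pairing the hydroxy with trifluoromethoxy or dimethylamino in place of the methoxy of compound 4 would test.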